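The compounds below may be only part of what the source reports. "The series", "measured", "known", "first", "only" and "open" are said of these compounds alone.

Compound 1 `Cc1cc(=O)c2c(O)c(CN(C(C)C)C(C)C)c(O)c([C@H]3CCN(C)C[C@H]3O)c2o1`: 22%
Compound 2 `Cc1oc2c([C@H]3CCN(C)C[C@H]3O)c(O)cc(O)c2c(=O)c1C(O)c1ccc(Cl)cc1`: 3%
Compound 3 `Cc1oc2c([C@H]3CCN(C)C[C@H]3O)c(O)cc(O)c2c(=O)c1C(O)c1ccc(F)c(Br)c1`: 6%

In a functional assay on Caco-2 cells (Homo sapiens) for inhibition, read by MTT assay, with a stated time of 48 h, tested at 10 uM (a higher number here means more inhibition of growth at the concentration tested, a lower number less inhibition of growth), compound 3 gives 6%. That is level, within the scatter, with compound 2, and clearly under compound 1, the only one of the three that differs beyond the scatter.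

Compound 4 `CCOc1ccc(Br)c(C(O)c2c(C)oc3c([C@H]4CCN(C)C[C@H]4O)c(O)cc(O)c3c2=O)c1` differs from compound 3 by 2-bromo-5-ethoxyphenyl in place of 3-bromo-4-fluorophenyl on a saturated chain carbon bound to an aromatic carbon and an oxygen on a saturated carbon.

Within the data shown here, only one measured step swaps the aromatic group at this place: a number 3 percentage points higher from compound 2 to compound 3 (within the scatter). It was small, so no change beyond the scatter is expected in this assay. The expected step is a number 1 percentage points higher from compound 3 to compound 4 (within the scatter).

The estimate for compound 4 is 7%, with an expected range from 0% to 19%.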

Compound 4, percent growth inhibition at one concentration: 5%
For compound 4 the middle estimate is 2 percentage points above the measured one; measured number inside the range.
By their numbers in this assay, from the lowest: compounds 2, 4 and 3 (each within the scatter of the next); then compound 1.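

In this assay, the change to 2-bromo-5-ethoxyphenyl is a number 1 percentage points lower from compound 3 to compound 4 (within the scatter) and a number 2 percentage points higher from compound 2 to compound 4 (within the scatter). A third aromatic group at this place, now one that adds a hydrogen-bond acceptor and carries its bromine at a different ring position, therefore leaves the number level with the other two. Nothing available explains this lack of change.

From the compounds shown here alone, whether any group at this place can move the number beyond the scatter remains open. An aromatic ring carrying an amine or a carboxylic acid, for example, could still behave differently.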